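This account rests on a few compounds, and the source may have more. Where it says the series, first, only, none or still open, it means among the compounds named here.

Compound 1 `O=C(NC(=S)N1CCc2cc(OCc3ccccc3)ccc21)c1ccccc1`: 45200 nM in an ADME assay on Huh-7 cells (Homo sapiens) for cytotoxicity; on this read-out higher numbers stand for lower toxicity in this test and lower numbers for higher toxicity in this test.
Compound 2 `O=C(NC(=S)N1CCc2cccc(OCc3ccccc3)c21)c1ccccc1`: a limit of the test, > 50000 nM.
Compound 3 `O=C(NC(=S)N1CCc2c(OCCCCCOc3ccc(Cl)cc3)cccc21)Oc1ccccc1`: a limit of the test, > 50000 nM.

Compound 3 therefore stands at the upper edge of what this assay reports, with no number of its own, and compound 2 stands at the same edge. Within the data shown here, compound 1 is the one compound of the three with a value rather than a limit, and it lies a little below that edge. Among the measured compounds shown here, no two of the measured compounds differ in a single place, so no step between measured compounds can be read from them.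

Compound 4 `N#Cc1ccc(C(=O)NC(=S)N2CCc3c(OCCCCCOc4ccc(Cl)cc4)cccc32)cc1` has not yet been measured. It differs from compound 3 in one place: 4-cyanophenyl in place of phenoxy on a carbonyl carbon whose other neighbour is an amide-type nitrogen.

Given (the limit of > 50000 nM in this assay, at which 2 of the 3 values shown sit), compound 4 is expected to behave like its neighbours, and the step from compound 3 to compound 4 is estimated as an at least 1.0-fold lower number from compound 3 to compound 4 (0.01 log units; that floor lies within the scatter), none beyond the scatter. Compound 4 is accordingly estimated at 48000 nM, within 24000 nM to 100000 nM, with a real chance that this assay again reports only its limit.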

Compound 4, half-maximal cytotoxic concentration: > 50000 nM
Compound 4 ended at the assay's limit; the forecaster's own chance of this, stated with the estimate: 55%; middle value at least 1.0-fold (0.01 log units) from the limit.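

Compound 3 and compound 4 both end at a limit in this assay rather than at a number, so the step from phenoxy to 4-cyanophenyl on the carbonyl carbon cannot be read between them: the limit of > 50000 nM in this assay, at which 3 of the 4 values shown sit.

The compounds shown leave open how far past that limit either compound lies, and whether this change alters the read-out at all.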